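The source may hold more compounds than are shown below. What is called first, only, known or untested is meant among the compounds shown, and "the series" means these compounds.

Compound 1, `O=C(NC1CCCCC1)N1CCN(c2nc(-c3ccc4ccccc4n3)no2)CC1`, gives 53 nM.
Compound 2, `COc1ccccc1NC(=O)N1CCC(c2noc(-c3ccc4ccccc4n3)n2)CC1`, gives 2400 nM.
Compound 3, `CC(=O)N1CCC(NC(=O)N2CCC(c3nc(-c4ccc5ccccc5n4)no3)CC2)CC1`, gives 500 nM.

All three were tested in a functional assay on Shh Light II cells (Mus musculus) for inhibition, read by a luciferase reporter; a lower number here means a stronger inhibitor, a higher number a weaker inhibitor. Among the three numbers, compound 3 stands second highest: compound 2 lies at a higher number than compound 3, a gap beyond the usual scatter, while compound 1 lies at a lower number than compound 3, also beyond the scatter. Compound 3 thus sits between a clearly stronger and a clearly weaker neighbour.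

Compound 4, `Cc1noc(C)c1NC(=O)N1CCC(c2nc(-c3ccc4ccccc4n3)no2)CC1`, has not yet been measured. It differs from compound 3 in one place: 3,5-dimethyl-1,2-oxazol-4-yl in place of 1-acetylpiperidin-4-yl on an amide-type nitrogen. A six-membered non-aromatic ring on the amide-type nitrogen gives way to a five-membered aromatic ring there. Compound 2, whose group at the corresponding position is also an aromatic ring, gives 2400 nM, the highest of the three. For the measured compounds named here, no pair among the measured compounds shows this same exchange, so the direction remains uncertain. The expected step is a 1.6-fold higher number from compound 3 to compound 4 (0.20 log units; within the scatter), a modest rise near the edge of the scatter. Compound 4 is therefore estimated at 800 nM, with a range from 200 nM to 3200 nM.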

Compound 4, half-maximal inhibitory concentration: 3000 nM
For compound 4 the middle estimate is 3.8-fold (0.57 log units) below the measured one, within the range that was stated.
By their numbers in this assay, from the lowest: compound 1; then compound 3; then compounds 2 and 4 (each within the scatter of the next).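

In this assay, for the compounds shown here, the exchange of 1-acetylpiperidin-4-yl for 3,5-dimethyl-1,2-oxazol-4-yl on the amide-type nitrogen gives a 6.0-fold higher number from compound 3 to compound 4 (0.78 log units; beyond the scatter), and this is the first reading of this position with the rest of the molecule held constant. The position is therefore sensitive to the group it carries, and in this one pair the five-membered aromatic ring gives the weaker inhibitor, although a single pair sets no general rule. Nothing measured here explains the step.

The exchange alters several features at once: the ring size, the aromatic character, the acetyl group and the two methyl groups, so the compounds shown cannot reveal which of these matters. On these data alone, a piperidin-4-yl group with a free amine in place of the acetyl, a tetrahydropyran-4-yl group or a plain phenyl ring at this position on the same core would help to separate these features, and whether any group here can do better than 1-acetylpiperidin-4-yl remains open.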